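A few compounds are considered here, and "the series" means these few. Any claim that something is new, unique, unknown or untested is made for them only; others in the source may bear on it.

Measured compounds:
- compound 1 `Cc1cc(C)c(Oc2cc(Nc3ccc(C#N)cc3)ncc2C(=O)NCc2cn(Cc3ccccc3[N+](=O)[O-])nn2)c(C)c1`: > 212000 nM
- compound 2 `Cc1cccc(Cn2cc(CNC(=O)c3cnc(Nc4ccc(C#N)cc4)cc3Oc3c(C)cc(C)cc3C)nn2)c1`: 114000 nM
- compound 3 `Cc1cc(C)c(Oc2cc(Nc3ccc(C#N)cc3)ncc2C(=O)NCc2cn(Cc3ccccc3C#N)nn2)c(C)c1`: > 219000 nM

Within the data shown here, in an ADME assay on MT4 cells (Homo sapiens) for cytotoxicity, read by MTT assay, with a stated time of 5 days (on this read-out higher numbers stand for lower toxicity in this test and lower numbers for higher toxicity in this test), compound 2 gives 114000 nM, the only number among the three. For compound 1 the value > 212000 nM is a limit of this assay, not a number. For compound 3 the value > 219000 nM is likewise a limit. Compound 4 `Cc1cc(C)c(Oc2cc(Nc3ccc(C#N)cc3)ncc2C(=O)NCc2cn(Cc3cccc(F)c3)nn2)c(C)c1` differs from compound 2 by fluoro in place of methyl on an aromatic carbon. Among the measured compounds shown here, the steps that bear on this change alter the same part of the molecule: an at least 1.8-fold lower number from compound 1 to compound 2 (0.26 log units; that floor lies within the scatter) and an at least 1.9-fold higher number from compound 2 to compound 3 (0.28 log units; that floor lies within the scatter), both floors within the scatter. Compound 4 is therefore expected to show a step of about a 1.2-fold higher number from compound 2 to compound 4 (0.09 log units; within the scatter), no change beyond the scatter. Compound 4 is estimated at 140000 nM, between 70000 nM and 280000 nM.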

Compound 4, half-maximal cytotoxic concentration: >= 204000 nM
Compound 4 gave a limit, no number; the forecaster's own chance of this, stated with the estimate: 40%; at least 1.4-fold (0.16 log units) between middle value and limit.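

In this assay, fluoro in place of methyl on an aromatic carbon gives an at least 1.7-fold higher number from compound 2 to compound 4 (0.25 log units; that floor lies within the scatter), so this change is not shown to go beyond the scatter, though a floor leaves the true size unknown. Compound 4 gives >= 204000 nM, which is a limit of the assay and not a number. The steps linking compound 4 to compound 1 and compound 3 cannot be read.

Going by these compounds, the true value of compound 4 stays open. So does whether chloro, methoxy or an amine on this aromatic carbon would give a number rather than a limit.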